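Furan-3-yl in Place of Methyl on the Shared Core

This account rests on a few compounds, and the source may have more. Where it says the series, first, only, none or still open, it means among the compounds named here.

Compound 1 `COC(=O)c1nc(C)n(-c2ccc(C(F)(F)F)cc2)n1`: in a functional assay on Jurkat cells (Homo sapiens) for inhibition, read by MTT assay, with a stated time of 72 h (a higher number here means a weaker inhibitor of growth, a lower number a stronger inhibitor of growth), compound 1 gives 9100 nM.
Compound 2 `COC(=O)c1nc(C)n(-c2ccc(OC)cc2)n1`: in this assay compound 2 gives only a limit, > 100000 nM.
Compound 3 `COC(=O)c1nc(C)n(-c2ccc(F)cc2)n1`: in this assay compound 3 gives 8700 nM.

Compound 1 holds the highest of the two numbers; compound 3 lies nearest, with a 1.0-fold lower number from compound 1 to compound 3 (0.02 log units; within the scatter). Compound 2 sits at the limit of the assay, (the limit of > 100000 nM in this assay, at which 1 of the 3 values shown sits). The two large steps, an at least 10-fold higher number from compound 1 to compound 2 (1.04 log units; beyond the scatter) and an at least 11-fold lower number from compound 2 to compound 3 (1.06 log units; beyond the scatter), both concern the substituent on the aromatic carbon of the phenyl ring. Compound 4 `COC(=O)c1nc(-c2ccoc2)n(-c2ccc(C(F)(F)F)cc2)n1` differs from compound 1 at another place: furan-3-yl in place of methyl on an aromatic carbon. Among the compounds with values here, no measured step touches this position, so none of them bears on the change. With no guide, compound 4 is estimated at 7000 nM, ranging from 1500 nM to 40000 nM, which means an expected step of a 1.3-fold lower number from compound 1 to compound 4 (0.11 log units; within the scatter) in this assay.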

Compound 4, concentration for 50% growth inhibition: 97200 nM
Compound 4: middle estimate off by 14-fold (1.14 log units), on the low side, outside the stated range (above it).
By their numbers in this assay, from the lowest: compounds 3 and 1 (each within the scatter of the next); then compound 4. At a limit, above all of these: compound 2.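

In this assay, furan-3-yl in place of methyl on this aromatic carbon gives an 11-fold higher number from compound 1 to compound 4 (1.03 log units; beyond the scatter), so compound 4 is a weaker inhibitor of growth than compound 1. The earlier compounds shown here varied only the substituent on the phenyl ring, and this step shows that the number also moves strongly at this second place on the shared core. No measurement shown here accounts for the step. On these data alone, whether the ring as a whole or its oxygen drives the change stays open. A phenyl ring, an ethyl chain or an amine at this place would help to separate the two.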